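Removing a Methoxy Group from Two Different Cores

A few compounds are considered here, and "the series" means these few. Any claim that something is new, unique, unknown or untested is made for them only; others in the source may bear on it.

Measured compounds:
- compound 1, `COc1cc(C(=O)NNC(=S)Nc2csc(-c3ccccc3)c2)cc(OC)c1OC`: 32000 nM
- compound 2, `COc1cc(OC)cc(C(=O)NNC(=S)Nc2csc(-c3ccccc3)c2)c1`: 30000 nM
- compound 3, `COc1ccc(-c2cc(Nc3nnc(-c4ccc(C)cc4)s3)cs2)cc1`: "not determined" (no result reported)

The study measures how well these compounds hold back the growth of mouse melanoma cells in a functional assay on B16-F10 cells (Mus musculus) for inhibition, read by colorimetric assay and MTT assay, with a stated time of 72 h; on this read-out higher numbers stand for weaker inhibition and lower numbers for stronger inhibition. Compound 1 gives 32000 nM and compound 2 gives 30000 nM. The only difference between them is hydrogen in place of methoxy on an aromatic carbon. That change made a 1.1-fold lower number from compound 1 to compound 2 (0.03 log units; within the scatter), so the two numbers cannot be told apart.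

Compound 3, built on a different core, has "not determined" (no result reported) in this assay, so no number stands for it. The difference between the core of compound 1 and the core of compound 3 is not broken down here.

Compound 4, `Cc1ccc(-c2nnc(Nc3csc(-c4ccccc4)c3)s2)cc1`, has not yet been measured. It differs from compound 3 by hydrogen in place of methoxy on an aromatic carbon. Among the measured compounds shown here, this is the same kind of change as the one from compound 1 to compound 2, but not the same: in compound 1 the methoxy that leaves sits ortho to two methoxy groups (2 heavy atoms each) and para to a large group, whereas in compound 3 it sits para to a large group only.

Because the earlier step was a 1.1-fold lower number from compound 1 to compound 2 (0.03 log units; within the scatter), the step from compound 3 to compound 4 in this assay is also expected to be small. With no number for compound 3 and a different core, the estimate for compound 4 is uncertain and rests on the level seen for compound 1 and compound 2: compound 4 is expected to give about 25000 nM, somewhere between 4000 nM and 120000 nM.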

Compound 4, half-maximal inhibitory concentration: 4000 nM
Compound 4: the middle estimate sits 6.3-fold (0.80 log units) above what was measured, within the range that was stated.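

In this assay compound 4 gives 4000 nM, but compound 3 has no number there, so the change from 4-methoxyphenyl to phenyl between compound 3 and compound 4 cannot be read as a step. The compounds shown leave open what that change does on the core of compound 3, and whether it resembles a 1.1-fold lower number from compound 1 to compound 2 (0.03 log units; within the scatter). Nothing given here bears on this result.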